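Urea series cytotoxicity notes: from compound 2 to compound 4

The source may hold more compounds than are shown below. What is called first, only, known or untested is meant among the compounds shown, and "the series" means these compounds.

Compound 2 `Cc1cc(NC(=O)Nc2cccc(Cl)c2)c2ccccc2n1` stands at the edge of the measured range in an ADME assay on BJ cells (Homo sapiens) for cytotoxicity, with a stated time of 72 h; on this read-out lower numbers stand for an effect already at smaller amounts and higher numbers for an effect only at larger amounts of compound: its value of > 25000 nM is a limit, not a number. Compound 1 `Cc1ccc(NC(=O)Nc2cc(C)nc3ccccc23)cc1` likewise returns a limit, > 25000 nM. Compound 3 `COc1cccc(NC(=O)Nc2cc(C)nc3ccccc23)c1` gives a number, 27000 nM. The two steps that touch compound 2 are a step that the two limits leave unreadable from compound 1 to compound 2 and a step that the limit leaves unreadable from compound 2 to compound 3, both unreadable due to the limit of > 25000 nM in this assay, at which 2 of the 3 values shown sit. Compound 4 `Cc1cc(NC(=O)Nc2cccnc2)c2ccccc2n1` differs from compound 2 by pyridin-3-yl in place of 3-chlorophenyl on an amide-type nitrogen. Going by the values given here, no measured step bears directly on this change, and the values seen so far give no hint of an effect beyond the scatter in this assay. For compound 4 the expected value is 30000 nM, within 15000 nM to 60000 nM, the estimated step being a step that the limit leaves unreadable from compound 2 to compound 4 and most likely reported as a limit.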

Compound 4, half-maximal effective concentration: > 25000 nM
Compound 4: no number, only a limit; the forecaster's own chance of this, stated with the estimate: 75%; the middle value lies beyond the limit too.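

The steps from compound 2 and compound 1 to compound 4 cannot be read in this assay because all three compounds return only a limit: the limit of > 25000 nM in this assay, at which 3 of the 4 values shown sit.

As far as these compounds go, whether pyridin-3-yl in place of 3-chlorophenyl shifts the read-out at all remains open.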